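This account rests on a few compounds, and the source may have more. Where it says the series, first, only, none or still open, it means among the compounds named here.

Three compounds share one core and differ only in one group on an aromatic carbon of that core: compound 1 is `Cc1noc(-c2cc3ccccc3[nH]2)n1`, compound 2 is `COc1ccc2[nH]c(-c3nc(C)no3)cc2c1` and compound 3 is `Cc1noc(-c2cc3cc(F)ccc3[nH]2)n1`. In a functional assay on MIA PaCa-2 cells (Homo sapiens) for antiproliferative activity, read by WST assay, with a stated time of 72 h (on this read-out higher numbers stand for weaker inhibition and lower numbers for stronger inhibition), compound 1 gives 30500 nM. For compound 2 only a limit is recorded, > 50000 nM, which is the limit of > 50000 nM in this assay, at which 1 of the 3 values shown sits. Compound 3 gives 19400 nM, the lowest of the two numbers, although the step of a 1.6-fold lower number from compound 1 to compound 3 (0.20 log units; within the scatter) lies within the scatter. The other steps are an at least 1.6-fold higher number from compound 1 to compound 2 (0.21 log units; that floor lies within the scatter) and an at least 2.5-fold lower number from compound 2 to compound 3 (0.41 log units; beyond the scatter).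

Compound 4 is `Fc1ccc2[nH]c(-c3nc(-c4ccc(Cl)cc4)no3)cc2c1`. Its change from compound 3 sits on another part of the core: 4-chlorophenyl in place of methyl on an aromatic carbon. Every measured step concerns small groups on the other ring, so none of them bears directly on this much larger replacement, and the direction of its effect cannot be read from them. Compound 4 is expected to give about 8000 nM, with a range from 1500 nM to 40000 nM. The expected step is a 2.4-fold lower number from compound 3 to compound 4 (0.38 log units; beyond the scatter).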

Compound 4, half-maximal inhibitory concentration: > 50000 nM
Compound 4: only a limit was reported (the forecaster's own chance of this, stated with the estimate: 15%); at least 6.2-fold (0.79 log units) between middle value and limit.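

In this assay, placing 4-chlorophenyl in place of methyl gives an at least 2.5-fold higher number from compound 3 to compound 4 (0.41 log units; beyond the scatter). This is the first change shown on the five-membered aromatic ring with 2 nitrogen and 1 oxygen, and it shows that this carbon is not indifferent to what it carries: with the fluoro group held constant, the larger group weakens inhibition by a step beyond the usual scatter. The result for compound 4 is a limit, not a number, so the true size of the loss stays unknown: the limit of > 50000 nM in this assay, at which 2 of the 4 values shown sit.

With only methyl and 4-chlorophenyl shown at this carbon, it remains open whether the loss comes from the phenyl ring itself or from its chlorine. Going by these compounds, it is also open whether a plain phenyl, a longer chain such as propyl or an amine here would keep the activity of compound 3.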